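The source may report more compounds than this note shows. Statements on the series, on what has been measured and on what is new or still open speak of the compounds shown alone.

In a functional assay on K562 cells (Homo sapiens) for antiproliferative activity, read by MTT assay, with a stated time of 5 days (on this read-out lower numbers stand for stronger inhibition and higher numbers for weaker inhibition), compound 1 `COc1ccc(C=C(C(=O)c2cc(OC)c(OC)c(OC)c2)c2ccc(C)cc2)cc1` gives 760000 nM, and compound 2 `COc1ccc(C=C(C(=O)c2cc(OC)c(OC)c(OC)c2)c2ccc(C)cc2)cc1F` gives 570000 nM. Compound 2 therefore stands within the scatter of compound 1, and the pair sets no order between them. Compound 3 `COc1ccc(C=C(C(=O)c2cc(OC)c(OC)c(OC)c2)c2ccc(C)cc2)cc1O` carries hydroxy in place of fluoro on an aromatic carbon, ortho to a methoxy group, turning the 3-fluoro-4-methoxyphenyl into 3-hydroxy-4-methoxyphenyl: hydroxy in place of fluoro on an aromatic carbon. Among the measured compounds shown here, only one measured step bears on this carbon, fluoro in place of hydrogen, namely a 1.3-fold lower number from compound 1 to compound 2 (0.12 log units; within the scatter), which stays within the scatter. That step involves no hydrogen-bond donor, so it offers only weak guidance for a hydroxy group. A modest move to a lower number in this assay is nevertheless expected, with the estimated step being a 2.9-fold lower number from compound 2 to compound 3 (0.45 log units; beyond the scatter). Compound 3 is estimated at 200000 nM, within a range of 30000 nM to 700000 nM.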

Compound 3, half-maximal inhibitory concentration: 32000 nM
Estimate against measurement, compound 3: 6.3-fold (0.80 log units) above; low and high end bracket the measured number.
By their numbers in this assay, from the lowest: compound 3; then compounds 2 and 1 (each within the scatter of the next).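

In this assay this carbon turns out to be sensitive to what it carries: hydroxy in place of fluoro gives an 18-fold lower number from compound 2 to compound 3 (1.25 log units; beyond the scatter) and hydroxy in place of hydrogen gives a 24-fold lower number from compound 1 to compound 3 (1.38 log units; beyond the scatter) while the earlier swap of fluoro for hydrogen stayed within the scatter. The response therefore goes with hydroxy alone among the three groups tried here, and hydroxy is also the only one of them counted as a hydrogen-bond donor, though three compounds cannot tie the step to that count. Nothing measured here accounts for the size of these steps.

The compounds shown leave open whether an amine or a carboxylic acid on this carbon would follow hydroxy or stay with hydrogen and fluoro. They also leave open whether hydroxy would give a similar step on another carbon of this ring.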